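This account rests on a few compounds, and the source may have more. Where it says the series, first, only, none or still open, it means among the compounds named here.

Measured compounds in an assay on isolated protein for inhibition of Trypsin (Homo sapiens), read by fluorescence, with a stated time of 15 min, tested at 50 uM; on this read-out higher numbers stand for more inhibition at the one concentration tested (going by the name of the read-out) and lower numbers for less inhibition:
- compound 1 `C[C@@](NC(=O)[C@H](CCCCN)NC(=O)[C@H](CCCNC(=N)N)NC(=O)c1ccccc1)(C(N)=O)c1ccccc1` gives 20.7%
- compound 2 `CN(C(=O)[C@H](CCCCN)NC(=O)[C@H](CCCNC(=N)N)NC(=O)c1ccccc1)[C@@H](C(N)=O)c1ccccc1` gives <= 5%, a limit of the assay rather than a number
- compound 3 `N=C(N)NCCC[C@H](NC(=O)c1ccccc1)C(=O)N[C@@H](CCCCN)C(=O)N(CC(N)=O)c1ccccc1` gives <= 5%, again a limit of the assay rather than a number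

Within the data shown here, compound 1 holds the only number in this assay; the other two results stop at a limit, as the limit of <= 5% in this assay, at which 2 of the 3 values shown sit, records. Two steps start from compound 1. In one, a number at least 15.7 percentage points lower from compound 1 to compound 2 (beyond the scatter) reflects a change on a carbonyl carbon. In the other, a number at least 15.7 percentage points lower from compound 1 to compound 3 (beyond the scatter) reflects a different change at the same place. Both alter how the amide nitrogen is substituted and remove the 1-carbamoyl-1-phenylethyl group entirely.

Compound 4 `CCC(NC(=O)[C@H](CCCCN)NC(=O)[C@H](CCCNC(=N)N)NC(=O)c1ccccc1)(C(N)=O)c1ccccc1` is not yet measured. It differs from compound 1 by 1-carbamoyl-1-phenylpropyl in place of 1-carbamoyl-1-phenylethyl on an amide-type nitrogen. Among the measured compounds shown here, this lengthens one chain by a single carbon and keeps the amide hydrogen, which neither measured step does, so no measured step bears directly on it. With so small a change, the expectation is a step of a number 1.7 percentage points lower from compound 1 to compound 4 (within the scatter), within the scatter. Compound 4 is therefore estimated at 19%, between 5% and 33%.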

Compound 4, a percentage reported as inhibition, at one concentration (the size of the read-out at that concentration, not a potency): 8.7%
The estimate for compound 4 lay 10.3 percentage points above the measured number; the measured number falls inside the stated range.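

In this assay, 1-carbamoyl-1-phenylpropyl in place of 1-carbamoyl-1-phenylethyl on an amide-type nitrogen gives a number 12 percentage points lower from compound 1 to compound 4 (beyond the scatter). The earlier steps shown here removed the 1-carbamoyl-1-phenylethyl group entirely, whereas this change keeps the carbamoyl group, the phenyl ring and the amide hydrogen and lengthens one chain by a single carbon. Even this small change at this position therefore moves the read-out beyond the scatter, and compound 1 remains the highest of the compounds shown.

As far as these compounds go, whether a 1-carbamoyl-1-phenylbutyl group, with a longer chain still, or an amine at the end of that chain would lower the number further remains open. Any further fall could be followed only a short way in this assay, where the results soon reach a limit: the limit of <= 5% in this assay, at which 2 of the 4 values shown sit.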